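Chloro in Place of Methyl: One Step from Compound 1

The source may hold more compounds than are shown below. What is called first, only, known or untested is meant among the compounds shown, and "the series" means these compounds.

Two compounds have so far been measured in a functional assay on CWR22R cells (Homo sapiens) for inhibition; on this read-out higher numbers stand for weaker inhibition and lower numbers for stronger inhibition:

Compound 1 `CCn1c(=O)/c(=C2\Sc3ccccc3N2C)s/c1=C\c1ccncc1Nc1ccccc1C` gives 470 nM.
Compound 2 `CCn1c(=O)/c(=C2\Sc3ccc(C)cc3N2C)s/c1=C\c1ccncc1Nc1ccccc1F` gives 150 nM.

Of these two numbers, compound 1 holds the higher one, so it is the weaker inhibitor of the pair; compound 2 sits lower, and that gap lies beyond the usual scatter. The two differ in more than one place, so no single change can be read from them.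

Compound 3 `CCn1c(=O)/c(=C2\Sc3ccccc3N2C)s/c1=C\c1ccncc1Nc1ccccc1Cl` keeps everything of compound 1 except one group: chloro in place of methyl on an aromatic carbon. Going by the values given here, no measured pair shows this exact change on its own, so there is no direct precedent. The step of a 1.3-fold lower number from compound 1 to compound 3 (0.13 log units; within the scatter) is expected to be small, with a slight lean toward a lower number, but quite possibly within the scatter. For compound 3 the expected value is 350 nM, estimated to lie between 150 nM and 800 nM.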

Compound 3, half-maximal inhibitory concentration: 460 nM
Estimate against measurement, compound 3: 1.3-fold (0.12 log units) below, and the stated range covers the measured number.
By their numbers in this assay, from the lowest: compound 2; then compounds 3 and 1 (each within the scatter of the next).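

Going by these compounds alone, the step of a 1.0-fold lower number from compound 1 to compound 3 (0.01 log units; within the scatter) is the first single change that can be read in this assay. It shows that on this aromatic carbon, ortho to a large group, 2-methylphenyl and 2-chlorophenyl cannot be told apart, so exchanging one heavy atom, a carbon for a chlorine, leaves no mark beyond the scatter on this read-out. Nothing available here speaks to why the two groups read alike.

This single swap does not tell how other groups would read at this place, such as a methoxy, an amine or a carboxylic acid, or how the read-out would stand with only hydrogen there. From the compounds shown here alone, whether the same swap would read alike elsewhere on the core of compound 1 also stays open.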